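The source may report more compounds than this note shows. Statements on the series, on what has been measured and on what is new or still open speak of the compounds shown alone.

Three analogues of one shared core have been run in a functional assay on A-375 cells (Homo sapiens) for antiproliferative activity, read by trypan blue exclusion, with a stated time of 48 h, tested at 5 uM; on this read-out higher numbers stand for a weaker effect at the one concentration tested and lower numbers for a stronger effect: compound 1 `CCCCCCC#Cc1ccc(S(=O)(=O)Nc2cccc(-c3csc(NC(C)=O)n3)c2)cc1`, compound 2 `CCCCCCCCC#Cc1ccc(S(=O)(=O)Nc2cccc(-c3csc(NC(C)=O)n3)c2)cc1` and compound 3 `CCCCCCCCc1ccc(S(=O)(=O)Nc2cccc(-c3csc(NC(C)=O)n3)c2)cc1`. In this assay compound 1 gives 12.8% and compound 2 gives 8.9%. For compound 3 this assay reports only a limit, < 1%, as noted in the limit of < 1% in this assay, at which 1 of the 3 values shown sits. Compound 4 `CCCCCCc1ccc(S(=O)(=O)Nc2cccc(-c3csc(NC(C)=O)n3)c2)cc1` has not been measured.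

The change hydrogen in place of ethyl on a saturated chain carbon, six bonds along the chain from a triple-bonded carbon made the step of a number 3.9 percentage points higher from compound 2 to compound 1 (within the scatter). The same kind of change, (hydrogen in place of ethyl on a saturated chain carbon, six bonds along the chain from an aromatic carbon), is now placed on the core of compound 3, which differs from the core of compound 2 by octyl in place of dec-1-yn-1-yl on an aromatic carbon; the chain position is counted from an aromatic carbon rather than from a triple-bonded carbon. The steps of a number at least 11.8 percentage points lower from compound 1 to compound 3 (beyond the scatter) and a number at least 7.9 percentage points lower from compound 2 to compound 3 (that floor lies within the scatter) frame compound 3.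

In this assay a small step is expected from the earlier pair, a number at least 5 percentage points higher from compound 3 to compound 4 (that floor lies within the scatter), resting on a number 3.9 percentage points higher from compound 2 to compound 1 (within the scatter). Compound 4 is estimated at 6%, between 1% and 20%.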

Compound 4, a percentage reported as activity, at one concentration (the size of the read-out at that concentration, not a potency): < 1%
Compound 4: only a limit was reported; the forecaster's own chance of this, stated with the estimate: 30%; middle value at least 5 percentage points from the limit.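

In this assay compound 4 gives < 1%, which is a limit of the assay and not a number, and compound 3 also carries only a limit, so the step between them cannot be read because both sit at that limit: the limit of < 1% in this assay, at which 2 of the 4 values shown sit. With hexyl in place of the alkynyl chains, the comparisons show a number at least 11.8 percentage points lower from compound 1 to compound 4 (beyond the scatter) and a number at least 7.9 percentage points lower from compound 2 to compound 4 (that floor lies within the scatter). Whether hydrogen in place of ethyl behaves on the core of compound 3 as it did on the core of compound 2 is therefore not shown, neither as a match nor as a departure.

Going by these compounds, whether compound 3 and compound 4 differ at all remains open. So does how a butyl chain, or an amine or a carboxylic acid in place of the hexyl chain, would read in this assay.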